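A few compounds are considered here, and "the series" means these few. Any claim that something is new, unique, unknown or untested is made for them only; others in the source may bear on it.

Of the compounds shown here, three built on one shared core have been measured in an assay on isolated protein for inhibition of ubiquitin carboxyl-terminal hydrolase 7 (Homo sapiens), with stated times of 30 min and 2 h; on this read-out lower numbers stand for stronger inhibition and higher numbers for weaker inhibition. Compound 1 `CC(C)NCc1ccc(-c2c3ncn(CC4(O)CCN(Cc5ccc(-c6ccco6)cc5Cl)CC4)c(=O)c3nn2C)cc1` gives 29.1 nM. Compound 2 `CN(C)Cc1ccc(-c2c3ncn(CC4(O)CCN(Cc5ccc(-c6ccco6)cc5Cl)CC4)c(=O)c3nn2C)cc1` gives 131 nM, and compound 3 `Cn1nc2c(=O)n(CC3(O)CCN(Cc4ccc(-c5ccco5)cc4Cl)CC3)cnc2c1-c1ccc(C(=N)N)cc1` gives 87.5 nM. Compound 3 therefore holds the second highest of the three numbers: its separation from compound 2 is a 1.5-fold lower number from compound 2 to compound 3 (0.18 log units; within the scatter), while the step of a 3.0-fold higher number from compound 1 to compound 3 (0.48 log units; beyond the scatter) sets it clearly apart from compound 1.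

Compound 4 `Cn1nc2c(=O)n(CC3(O)CCN(Cc4ccc(-c5ccco5)cc4Cl)CC3)cnc2c1-c1ccc(CNC2CC2)cc1` has not yet been measured. Its change from compound 3 is a group of 5 heavy atoms (4 carbon, 1 nitrogen; one three-membered non-aromatic ring of carbon only) in place of a group of 3 heavy atoms (1 carbon, 2 nitrogen; no ring), on an aromatic carbon. The measured step that bears most on this is a 3.0-fold higher number from compound 1 to compound 3 (0.48 log units; beyond the scatter), since compound 1 carries an isopropylamino on a saturated chain carbon, a group of the same count of heavy atoms as the one entering here, on an aromatic carbon of the same ring. The step of a 4.5-fold higher number from compound 1 to compound 2 (0.65 log units; beyond the scatter) shows that exchanging one amine substituent for another at that chain carbon, dimethylamino in place of isopropylamino, shifted the number only modestly. The move to compound 4 is thus expected to roughly undo the first of these steps and give a lower number, estimated as a 2.5-fold lower number from compound 3 to compound 4 (0.40 log units; beyond the scatter). Compound 4 is expected to come in at 35 nM, within a range from 12 nM to 100 nM.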

Compound 4, half-maximal inhibitory concentration: 54.1 nM
Beside the measured number, compound 4's estimate is 1.5-fold (0.19 log units) below it, and the stated range covers the measured number.
By their numbers in this assay, from the lowest: compounds 1, 4, 3 and 2 (each within the scatter of the next, the first and the last beyond it).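

Placing a (cyclopropylamino)methyl group on this aromatic carbon, para to a large group, in place of the group carried by compound 3 gives a 1.6-fold lower number from compound 3 to compound 4 (0.21 log units; within the scatter) in this assay and so does not separate the two groups. The amine substituents are easier to read: cyclopropylamino in place of dimethylamino gives a 2.4-fold lower number from compound 2 to compound 4 (0.38 log units; beyond the scatter) and is a real separation, whereas cyclopropyl in place of isopropyl on the amine nitrogen gives a 1.9-fold higher number from compound 1 to compound 4 (0.27 log units; within the scatter) and cannot be told apart from no change. Among these three amines, compound 2 is the only one with two carbon substituents on the nitrogen, and it now stands apart from both compound 1 and compound 4, although no measurement shown here offers a reason for this.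

An unsubstituted aminomethyl group or a pyrrolidine ring at the same chain carbon would show how far this split among the amines extends. A hydroxymethyl group on the same aromatic carbon would test whether a nitrogen is needed there at all.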